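This account rests on a few compounds, and the source may have more. Where it says the series, first, only, none or still open, it means among the compounds named here.

Within the data shown here, compound 3 `CCCC1Oc2ccc(Oc3ccccc3)cc2C=C1CN(O)C(N)=O` gives 880 nM in an assay (Cavia porcellus) for inhibition of Polyunsaturated fatty acid 5-lipoxygenase (Homo sapiens) (on this read-out higher numbers stand for weaker inhibition and lower numbers for stronger inhibition), the highest of the three numbers measured so far; compound 2 `CC1Oc2ccc(Oc3ccccc3)cc2C=C1CN(O)C(N)=O` gives 120 nM and compound 1 `CCOC(=O)CNC(=O)N(O)CC1=Cc2cc(Oc3ccccc3)ccc2OC1` gives 68 nM. Compound 4 `NC(=O)N(O)CC1=Cc2cc(Oc3ccccc3)ccc2OC1c1ccccc1` differs from compound 3 by phenyl in place of propyl on a saturated ring carbon. Among the measured compounds shown here, the only measured step bearing on this place is a 7.3-fold higher number from compound 2 to compound 3 (0.87 log units; beyond the scatter), a lengthening of the group on the same saturated ring carbon; no step to an aromatic group is available, so the analogy is loose. Extending that direction, a further weakening is expected, estimated for compound 4 as a 1.7-fold higher number from compound 3 to compound 4 (0.23 log units; within the scatter), with wide uncertainty. The estimate for compound 4 is 1500 nM, between 300 nM and 7000 nM.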

Compound 4, half-maximal inhibitory concentration: 310 nM
The estimate for compound 4 lay 4.8-fold (0.68 log units) above the measured number; the measured number falls inside the stated range.
By their numbers in this assay, from the lowest: compounds 1 and 2 (each within the scatter of the next); then compound 4; then compound 3.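

Working notes on the saturated ring carbon next to the ring oxygen: in this assay, the aromatic phenyl group gives a 2.8-fold lower number from compound 3 to compound 4 (0.45 log units; beyond the scatter), so the number does not rise with heavy-atom count across methyl, propyl and phenyl. Phenyl still falls short of methyl, with a 2.6-fold higher number from compound 2 to compound 4 (0.41 log units; beyond the scatter), leaving compound 2 lowest and compound 3 highest of these three compounds. No supporting evidence accounts for this order.

Open, from the compounds shown here alone, is whether a benzyl group or a pyridyl ring here would follow phenyl or propyl. Also open, going by these compounds, is whether substituents on the phenyl ring would shift the number.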